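This account rests on a few compounds, and the source may have more. Where it says the series, first, only, none or still open, it means among the compounds named here.

For the measured compounds named here, compound 2 `CC(=O)c1ccc(-c2cn3ccnc3c(-c3ccc4ncn(C5CCCCC5)c4c3)n2)cc1` has the lower of the two numbers so far in a functional assay on SN12C cells (Homo sapiens) for inhibition, read by sulforhodamine B assay, with a stated time of 48 h, tested at 10 uM (on this read-out higher numbers stand for more inhibition at the one concentration tested (going by the name of the read-out) and lower numbers for less inhibition), where compound 2 gives 6.33%, but the gap to compound 1 `Brc1cn2ccnc2c(-c2ccc3ncn(C4CCCCC4)c3c2)n1`, which gives 6.47%, lies within the scatter. Compound 3 `FC(F)(F)c1cccc(-c2cn3ccnc3c(-c3ccc4ncn(C5CCCCC5)c4c3)n2)c1` differs from compound 2 by 3-(trifluoromethyl)phenyl in place of 4-acetylphenyl on an aromatic carbon. Going by the values given here, the one measured step at this aromatic carbon, a number 0.1 percentage points lower from compound 1 to compound 2 (within the scatter), stayed within the scatter, so replacing the group there has so far moved the read-out little. Compound 3 is therefore expected to sit close to compound 2, the expected step of a number 0.7 percentage points higher from compound 2 to compound 3 (within the scatter) being within the scatter. The estimate for compound 3 is 7%, ranging from -6% to 22%.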

Compound 3, a percentage reported as inhibition, at one concentration (the size of the read-out at that concentration, not a potency): 8.3%
Compound 3: middle estimate off by 1.3 percentage points, on the low side; low and high end bracket the measured number.
By their numbers in this assay, from the lowest: compounds 2, 1 and 3 (each within the scatter of the next).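

Putting 3-(trifluoromethyl)phenyl on this aromatic carbon in place of 4-acetylphenyl gives a number 2 percentage points higher from compound 2 to compound 3 (within the scatter), and in place of bromo gives a number 1.8 percentage points higher from compound 1 to compound 3 (within the scatter). In this assay, a third group, one with no hydrogen-bond acceptor and with its substituent placed differently on the phenyl ring, therefore still leaves the read-out within the scatter of the other two. No available evidence bears on this result. From the compounds shown here alone, it remains open whether an amine or a carboxylic acid on this carbon would move the read-out beyond the scatter.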